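The source may hold more compounds than are shown below. What is called first, only, known or untested is meant among the compounds shown, and "the series" means these compounds.

Measured compounds and their values:

Compound 1 `COc1cc2c(cc1OC)C(CC(N)=O)CC2` gives 24.6% in a functional assay on the whole organism (strain Swiss albino) for inhibition, with Mus musculus as the target, in the writhing test, with stated times of 60 min and 15 min, at a dose of 100 mg/kg by the oral route; a lower number here means less inhibition, a higher number more inhibition at the dose given (going by the name of the read-out).
Compound 2 `CCCCNC(=O)CC1CCc2cc(OC)c(OC)cc21` gives 39.4% in this assay.
Compound 3 `COc1cc2c(cc1OC)C(CC(=O)NC1CCCC1)CC2` gives 37% in this assay.

Compound 3 stands second highest of the three numbers: its nearest neighbour is compound 2, whose value lies within the scatter of repeated measurements, and its furthest is compound 1, which lies well below it. The two measured steps away from compound 1 both raised inhibition: a number 14.8 percentage points higher from compound 1 to compound 2 (beyond the scatter) and a number 12.4 percentage points higher from compound 1 to compound 3 (beyond the scatter). The step between the two substituted amides, a number 2.4 percentage points lower from compound 2 to compound 3 (within the scatter), stayed within the scatter.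

Compound 4 `COc1cc2c(cc1OC)C(CC(=O)N1CCCC1)CC2` has not yet been measured. Its change from compound 3 is pyrrolidin-1-yl in place of cyclopentylamino on a carbonyl carbon. Among the measured compounds shown here, no measured step makes a change of this kind, in which the amide hydrogen is lost and the ring is joined through the nitrogen, so the closest guides are the steps 1>2 and 2>3, which show that substituted amides cluster near one another. The expectation for this assay is therefore a step near zero, a number 2 percentage points lower from compound 3 to compound 4 (within the scatter), with compound 4 estimated at 35%, within a range from 22% to 48%.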

Compound 4, a percentage reported as inhibition, in the whole organism at one dose (the size of the read-out at that dose, not a potency): 19.2%
Compound 4: the middle estimate sits 15.8 percentage points above what was measured; measured number below the stated range.
By their numbers in this assay, from the lowest: compounds 4 and 1 (each within the scatter of the next); then compounds 3 and 2 (each within the scatter of the next).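

In this assay, pyrrolidin-1-yl in place of cyclopentylamino gives a number 17.8 percentage points lower from compound 3 to compound 4 (beyond the scatter), and in place of butylamino it gives a number 20.2 percentage points lower from compound 2 to compound 4 (beyond the scatter). Against the plain amide, the same group gives a number 5.4 percentage points lower from compound 1 to compound 4 (within the scatter), so a substituent on this nitrogen does not by itself raise inhibition: compound 2 and compound 3 keep the amide hydrogen and stand high, whereas compound 4, which has lost it, does not, even though its five-membered ring matches that of compound 3 in size. No measurement at hand explains this drop.

On these data alone, it remains open whether the lost amide hydrogen or the ring joined through its nitrogen matters more, and a dimethylamino group on the carbonyl carbon would help separate the two. As far as these compounds go, a longer chain than butyl on the amide nitrogen also remains untested here.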